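A few compounds are considered here, and "the series" means these few. Any claim that something is new, unique, unknown or untested is made for them only; others in the source may bear on it.

Measured so far:
compound 1, `CN(C)c1nc(N)sc1C(=O)c1cnc2ccccn12`, 32%
compound 2, `Cc1ccc2ncc(C(=O)c3sc(N)nc3N(C)C)n2c1`, 23%
compound 3, `Cc1nc(N)sc1C(=O)c1cnc2ccccn12`, 53%

All three were tested in a functional assay on the whole organism (strain Sprague-Dawley) for inhibition, with Rattus norvegicus as the target, read by paw edema, with stated times of 1 h and 3 h, at a dose of 50 mg/kg by the oral route; a higher number here means more inhibition at the dose given (going by the name of the read-out), a lower number less inhibition. Compound 1 and compound 2 share a core and differ by methyl in place of hydrogen on an aromatic carbon; that change gave a number 9 percentage points lower from compound 1 to compound 2 (within the scatter). Compound 3 differs from compound 1 by methyl in place of dimethylamino on an aromatic carbon, which gave a number 21 percentage points higher from compound 1 to compound 3 (beyond the scatter) and leaves compound 3 with the highest of the three numbers. Compound 4, `Cc1ccn2c(C(=O)c3sc(N)nc3C)cnc2c1`, has not yet been measured in this assay . Within the data shown here, it differs from compound 3 by methyl in place of hydrogen on an aromatic carbon, the same kind of change as the one from compound 1 to compound 2; around the place they differ, since the entering methyl in compound 2 is two atoms from the ring nitrogen, whereas in compound 4 it is opposite the ring nitrogen. Beside the earlier step of a number 9 percentage points lower from compound 1 to compound 2 (within the scatter), the step from compound 3 to compound 4 is expected to be a number 9 percentage points lower from compound 3 to compound 4 (within the scatter), resting on the one measured pair that shows this kind of change. Compound 4 is therefore estimated at 44%, with an expected range from 26% to 62%.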

Compound 4, a percentage reported as inhibition, in the whole organism at one dose (the size of the read-out at that dose, not a potency): 66%
For compound 4 the middle estimate is 22 percentage points below the measured one; measured number outside the range, above it.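

In this assay, methyl in place of hydrogen on an aromatic carbon gave a number 13 percentage points higher from compound 3 to compound 4 (beyond the scatter). This shows that the size and direction of the step do not carry over unchanged from one core to the other in this small set, as the two measured pairs disagree: the same change on two cores in this assay, a number 9 percentage points lower (within the scatter) from compound 1 to compound 2 and a number 13 percentage points higher (beyond the scatter) from compound 3 to compound 4, 22 percentage points apart, beyond the scatter of two such steps. It does not show what sets the step, since the two pairs differ both in the other group, dimethylamino in compound 1 and methyl in compound 3, and in where the methyl enters, opposite the ring nitrogen only in compound 4, and two pairs cannot separate these.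

The compounds shown leave open whether a methyl opposite the ring nitrogen would also raise the number on the core of compound 1 that carries dimethylamino. They also leave open whether an ethyl, a methoxy or a chlorine at that place would follow the methyl of compound 4.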